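The compounds below may be only part of what the source reports. "The series", "measured", "known", "first", "only" and "open" are said of these compounds alone.

Measured so far in an ADME assay on NCM460 cells (Homo sapiens) for cytotoxicity, read by CCK-8 assay, with a stated time of 48 h; a higher number here means a weaker inhibitor, a lower number a stronger inhibitor (every entry is a limit of the assay, not a number):
- compound 1 `COc1ccc(/C=C\c2cc(OC)c(OC)c(OC)c2)cc1OCc1ccc(CN2CCCC[C@@H]2C(=O)O)cc1` gives > 50000 nM as a limit
- compound 2 `COc1ccc(/C=C\c2cc(OC)c(OC)c(OC)c2)cc1OCc1ccc(CN[C@H](C(=O)O)[C@H](C)O)cc1` gives > 50000 nM as a limit
- compound 3 `COc1ccc(/C=C\c2cc(OC)c(OC)c(OC)c2)cc1OCc1ccc(CN2CC[C@H](C(=O)O)C2)cc1` gives > 50000 nM as a limit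

Compound 3 therefore has no number, only its limit of > 50000 nM in this series. The three compounds share this position, with the limit of > 50000 nM in this assay, at which 3 of the 3 values shown sit, and all three carry carboxy.

Compound 4 `COc1ccc(/C=C\c2cc(OC)c(OC)c(OC)c2)cc1OCc1ccc(CN2CC[C@H](O)C2)cc1` differs from compound 3 at one place: hydroxy in place of carboxy on a saturated ring carbon with hydroxy in place of carboxy on a saturated ring carbon, so that 3-carboxypyrrolidin-1-yl becomes 3-hydroxypyrrolidin-1-yl.

The nearest measured steps are a step that the two limits leave unreadable from compound 1 to compound 3 and a step that the two limits leave unreadable from compound 2 to compound 3 and neither gives a size to work from. Both also keep the carboxy, so neither tests its removal. Among the measured compounds shown here, no compound without carboxy has yet been measured in this assay and the estimate is correspondingly loose.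

A move toward a lower number, meaning a stronger inhibitor, is expected, with an at least 16-fold lower number from compound 3 to compound 4 (1.22 log units; beyond the scatter) as the estimated step. A reading that stays at the limit remains quite possible. Compound 4 is estimated at 3000 nM with an expected range from 100 nM to 50000 nM in this assay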

Compound 4, half-maximal inhibitory concentration: 51000 nM
The estimate for compound 4 lay 17-fold (1.23 log units) below the measured number; the measured number lies above the stated range.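

In this assay no step to compound 4 can be read from compound 1, compound 2 or compound 3, because those three compounds give only a limit, not a number: the limit of > 50000 nM in this assay, at which 3 of the 4 values shown sit.

Whether hydroxy in place of carboxy on the saturated ring carbon shifts the reading in this assay stays open, as no compound shown that carries carboxy has a number.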